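A Change of Aryl Group in a Weakly Active Series

This account rests on a few compounds, and the source may have more. Where it says the series, first, only, none or still open, it means among the compounds named here.

The compounds here were tested in a functional assay on A549 cells (Homo sapiens) for antiproliferative activity, read by MTT assay, with a stated time of 48 h; a higher number here means a weaker inhibitor, a lower number a stronger inhibitor. Two of them reach no number at all. Compound 1 `Cc1cc(C)cc(-n2nncc2CN2C(=O)C3(C(C#N)=C(N)Oc4c3c3nc5ccccc5nc3c3ccccc43)c3ccccc32)c1` gives a limit, > 50000 nM. Compound 2 `Cc1ccc(Cl)cc1-n1nncc1CN1C(=O)C2(C(C#N)=C(N)Oc3c2c2nc4ccccc4nc2c2ccccc32)c2ccccc21` likewise gives only a limit, > 50000 nM. The step from one to the other, a step that the two limits leave unreadable from compound 1 to compound 2, therefore cannot be read. Of the three values shown, two are limits, as the limit of > 50000 nM in this assay, at which 2 of the 3 values shown sit, records. Compound 3 `N#CC1=C(N)Oc2c(N)cc3nc4ccccc4nc3c2C12C(=O)N(Cc1cnnn1-c1cccc(Br)c1)c1ccccc12` is the only one with a measured figure, 18900 nM, which makes it the single readable point in this assay, and still a weak inhibitor.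

Compound 4 `CCc1cccc(C)c1-n1nncc1CN1C(=O)C2(C(C#N)=C(N)Oc3c(N)cc4nc5ccccc5nc4c32)c2ccccc21` differs from compound 3 in one place: 2-ethyl-6-methylphenyl in place of 3-bromophenyl on an aromatic nitrogen. For the measured compounds named here, no measured step bears directly on this change, since the one step available, that from compound 1 to compound 2, has no readable size. Compound 1 and compound 2 both carry a substituted phenyl on the same aromatic nitrogen and both sit at the limit, but their shared core differs from that of compound 3, so they give no size for the change. The expectation is therefore no step beyond the scatter, with a real chance that compound 4 also reaches only the limit. Compound 4 is expected at 30000 nM, between 12000 nM and 50000 nM, an estimated step of a 1.6-fold higher number from compound 3 to compound 4 (0.20 log units; within the scatter).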

Compound 4, half-maximal inhibitory concentration: > 50000 nM
Compound 4: only a limit was reported; the forecaster's own chance of this, stated with the estimate: 40%; middle value at least 1.6-fold (0.22 log units) from the limit.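

In this assay, for the compounds shown here, 2-ethyl-6-methylphenyl in place of 3-bromophenyl gives the first readable step at this aromatic nitrogen: an at least 2.6-fold higher number from compound 3 to compound 4 (0.42 log units; beyond the scatter). The step from compound 1 to compound 2 cannot be read, so this pair alone shows that changing the aryl group here can shift the result beyond the scatter, and the shift is towards a weaker inhibitor. Compound 4 gives only a limit, so the printed size of the step is a minimum, and the series now rests largely on one boundary: the limit of > 50000 nM in this assay, at which 3 of the 4 values shown sit.

The compounds shown do not separate the removal of the bromine from the arrival of the ethyl and methyl groups, so neither change can be credited with the step on its own. From the compounds shown here alone, it also remains open whether a plain phenyl, or a phenyl carrying an amine or a carboxylic acid, would give a lower number than compound 3 at this nitrogen, which would show whether any aryl group here can improve on its weak activity.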